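Shortening the amine linker in the chalcone series

This account rests on a few compounds, and the source may have more. Where it says the series, first, only, none or still open, it means among the compounds named here.

Compound 1 `CCN(CCCCCCOc1ccc(C(=O)/C=C/c2ccc(N(C)C)cc2)c(O)c1)Cc1ccccc1` is the parent of the set. In an assay on isolated protein for inhibition of Amine oxidase [flavin-containing] A (Homo sapiens) (on this read-out lower numbers stand for stronger inhibition and higher numbers for weaker inhibition), compound 1 gives 31600 nM, the lowest of the three numbers, though each of the other two sits within the scatter of it. Compound 2 `CCN(CCCCCCOc1ccc(C(=O)/C=C/c2ccc(N(C)C)cc2)c(O)c1)Cc1ccccc1OC` gives 54300 nM and compound 3 `CCN(CCCCCCOc1ccc(C(=O)/C=C/c2ccc(N(C)C)cc2)c(O)c1)Cc1ccccc1N(C)C` gives 37800 nM. The step of a 1.7-fold higher number from compound 1 to compound 2 (0.24 log units; within the scatter) and the step of a 1.2-fold higher number from compound 1 to compound 3 (0.08 log units; within the scatter) both stay within the scatter, as does a 1.4-fold lower number from compound 2 to compound 3 (0.16 log units; within the scatter).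

Compound 4 `CCN(CCCCOc1ccc(C(=O)/C=C/c2ccc(N(C)C)cc2)c(O)c1)Cc1ccccc1` differs from compound 1 in the chain rather than on the benzyl ring: benzyl(ethyl)amino in place of 2-(benzyl(ethyl)amino)ethyl on a saturated chain carbon, four bonds along the chain from an oxygen on an aromatic ring. Within the data shown here, none of the measured steps touches this chain; all three concern substitution of the benzyl ring, and all three were within the scatter. Among the measured compounds shown here, there is therefore no measured step that bears on the change to compound 4, and no direction can be read from the series.

With that in mind, compound 4 is expected to give 31600 nM in this assay, with a range of 10000 nM to 100000 nM. This estimate means a step of no change at the digits printed from compound 1 to compound 4 (within the scatter), not expected to lie beyond the scatter.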

Compound 4, half-maximal inhibitory concentration: 77300 nM
Compound 4: the middle estimate sits 2.4-fold (0.39 log units) below what was measured, and the stated range covers the measured number.
By their numbers in this assay, from the lowest: compounds 1, 3, 2 and 4 (each within the scatter of the next, the first and the last beyond it).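

Among these compounds, the chain is the first place where a single change moves the number beyond the scatter: in this assay, there is a 2.4-fold higher number from compound 1 to compound 4 (0.39 log units; beyond the scatter), whereas the three changes on the benzyl ring all stayed within it. The benzyl(ethyl)amino group itself is kept and only the chain is shortened, so the saturated chain carbon four bonds along the chain from an oxygen on an aromatic ring is a place where this read-out responds, though modestly and towards weaker inhibition. Nothing available on these compounds accounts for the higher number with the shorter chain.

The compounds shown span only these chain lengths, so it remains open whether a longer chain than that of compound 1 would give a lower number or whether the number changes steadily with chain length. Also open, on these data alone, is whether methoxy or dimethylamino on the benzyl ring stays within the scatter on the shorter chain, and whether a piperidine in place of benzyl(ethyl)amino would shift the number at this position.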